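Notes on the step from compound 2 to compound 4

The source may report more compounds than this note shows. Statements on the series, on what has been measured and on what is new or still open speak of the compounds shown alone.

Measured in a functional assay on microsomes for inhibition, with a stated time of 1 h (on this read-out lower numbers stand for stronger inhibition and higher numbers for weaker inhibition), so far:
- compound 1 `CCOC(=O)c1cnn(-c2nc(-c3cccc(OC)c3OC)c(C#N)c(=O)n2C)c1N` gives 57 ug/mL
- compound 2 `CCOC(=O)c1cnn(-c2nc(-c3ccc(N(C)C)cc3)c(C#N)c(=O)n2C)c1N` gives 111 ug/mL
- compound 3 `Cn1c(NN)nc(-c2cccc(O)c2O)c(C#N)c1=O` gives 31 ug/mL

Compound 2 sits within the scatter of compound 1, while compound 3 gives a lower number, beyond the scatter. Going to compound 4 `CCOC(=O)c1cnn(-c2nc(-c3ccccc3Cl)c(C#N)c(=O)n2C)c1N` puts 2-chlorophenyl in place of 4-(dimethylamino)phenyl on an aromatic carbon. Among the measured compounds shown here, the one measured exchange of this group (a 1.9-fold higher number from compound 1 to compound 2 (0.29 log units; within the scatter)) stays within the scatter, so no step beyond the scatter is expected in this assay here. For the measured compounds named here, no 2-chlorophenyl compound has been measured, which keeps the range wide. The expected step (a 1.3-fold lower number from compound 2 to compound 4 (0.12 log units; within the scatter)) is small. For compound 4 the estimate is 85 ug/mL with an expected range from 35 ug/mL to 200 ug/mL on this read-out.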

Compound 4, half-maximal inhibitory concentration: 102 ug/mL
Beside the measured number, compound 4's estimate is 1.2-fold (0.08 log units) below it; low and high end bracket the measured number.
By their numbers in this assay, from the lowest: compounds 3, 1, 4 and 2 (each within the scatter of the next, the first and the last beyond it).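

In this assay, this aromatic carbon of the shared core accepts 2-chlorophenyl without a step beyond the scatter, whether it replaces 4-(dimethylamino)phenyl, a 1.1-fold lower number from compound 2 to compound 4 (0.04 log units; within the scatter), or 2,3-dimethoxyphenyl, a 1.8-fold higher number from compound 1 to compound 4 (0.25 log units; within the scatter). Compound 1, compound 2 and compound 4 therefore all lie within the scatter of each other, across three differently substituted phenyl groups. No supporting data bear on why this position reads so flat.

From the compounds shown here alone, whether a carboxylic acid or a primary amide on this phenyl would give a step beyond the scatter remains open.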